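Solubility notes on an aryloxy benzimidazole acid series

This account rests on a few compounds, and the source may have more. Where it says the series, first, only, none or still open, it means among the compounds named here.

Measured compounds:
- compound 1 `Cn1c(COc2cccc(C(=O)O)c2)nc2ccc(Oc3ccc4c(c3)OCC4)nc21`: 17 ug/mL
- compound 2 `Cc1ccc(Oc2ccc3nc(COc4cccc(C(=O)O)c4)n(C)c3c2)nc1`: 31 ug/mL

Two compounds of the series have been run in a physicochemical assay for solubility, read by HPLC, measured as thermodynamic solubility, with a stated time of 4 h, at pH 6.8; a lower number here means a less soluble compound, a higher number a more soluble compound. Compound 1 gives 17 ug/mL. Compound 2 gives 31 ug/mL, the higher of the two numbers, though its gap to compound 1 lies within the usual scatter of repeated runs, so the two cannot be ordered on these data.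

Compound 3 `Cc1cc(Cl)cnc1Oc1ccc2nc(COc3cccc(C(=O)O)c3)n(C)c2c1` is not yet measured. It departs from compound 2 in one place: 5-chloro-3-methylpyridin-2-yl in place of 5-methylpyridin-2-yl on an oxygen on an aromatic ring. The change adds a chlorine to the ring that sits on the oxygen and keeps the hydrogen-bond donor and acceptor count as counted.

Among the measured compounds shown here, no step between measured compounds exists to calibrate what such a change does here. On the shared core, and with only compound 2 as a direct point of comparison, the expectation is a modest step downward in this assay, from compound 2 to compound 3, of a 2.6-fold lower number from compound 2 to compound 3 (0.41 log units; beyond the scatter), possibly no larger than the scatter. Compound 3 is therefore estimated at 12 ug/mL, in a range from 5 ug/mL to 30 ug/mL.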

Compound 3, solubility: 3.9 ug/mL
Beside the measured number, compound 3's estimate is 3.1-fold (0.49 log units) above it, and the stated range ends above it.
By their numbers in this assay, from the lowest: compound 3; then compounds 1 and 2 (each within the scatter of the next).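

In this assay, among the compounds shown here, the group on an oxygen on an aromatic ring now has a step of its own: a 7.9-fold lower number from compound 2 to compound 3 (0.90 log units; beyond the scatter) is the first step that can be read, and it lies beyond the scatter. This position therefore registers in this read-out, and putting 5-chloro-3-methylpyridin-2-yl in place of 5-methylpyridin-2-yl moves the number although the hydrogen-bond donor and acceptor counts stay as they were, with compound 3 at 3.9 ug/mL on the same shared core. No measured property of these compounds accounts for the size of this step.

The two group names differ in both the 5-chloro and the 3-methyl, and this single step does not divide its size between them. Also open, from the compounds shown here alone, is how an amine or a morpholine on that same oxygen-linked ring would read in this assay on the shared core, and whether the chlorine alone would give a step beyond the scatter.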